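The source may hold more compounds than are shown below. What is called first, only, known or untested is meant among the compounds shown, and "the series" means these compounds.

Compound 1 `Cc1cc(Nc2nc(NCc3ccc(C#N)cc3)nc3ccccc23)n[nH]1`: 83 nM
Compound 2 `Cc1cc(Nc2nc(NCc3ccc(C(F)(F)F)cc3)nc3ccccc23)n[nH]1`: 1400 nM
Compound 3 `Cc1cc(Nc2nc(NCc3ccc(OC(F)(F)F)cc3)nc3ccccc23)n[nH]1`: 4100 nM

In an assay for inhibition of high affinity nerve growth factor receptor (Homo sapiens), read by HTRF, with a stated time of 30 min, in the presence of a further agent that is not named here (on this read-out higher numbers stand for weaker inhibition and lower numbers for stronger inhibition), compound 1 gives the lowest number of the three; the nearest is a 17-fold higher number from compound 1 to compound 2 (1.23 log units; beyond the scatter), and the furthest a 49-fold higher number from compound 1 to compound 3 (1.69 log units; beyond the scatter). Compound 4 `Cc1cc(Nc2nc(NCc3c(F)cccc3F)nc3ccccc23)n[nH]1` has not yet been measured. Its change from compound 1 is 2,6-difluorophenyl in place of 4-cyanophenyl on a saturated chain carbon bound to a nitrogen on an aromatic ring. Among the compounds with values here, no measured step puts two fluorines on that ring, so what bears on it is the removal of the cyano group, which in both measured steps, a 17-fold higher number from compound 1 to compound 2 (1.23 log units; beyond the scatter) and a 49-fold higher number from compound 1 to compound 3 (1.69 log units; beyond the scatter), gave a large rise. Compound 4 also loses the cyano group, and a rise beyond the scatter is therefore expected, though the entering group differs from those of compound 2 and compound 3, so the rise is expected to stay below a 49-fold higher number from compound 1 to compound 3 (1.69 log units; beyond the scatter). The estimate for compound 4 is 800 nM, in the range 200 nM to 4000 nM. That means an expected step of a 9.6-fold higher number from compound 1 to compound 4 (0.98 log units; beyond the scatter).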

Compound 4, half-maximal inhibitory concentration: 160 nM
Estimate against measurement, compound 4: 5.0-fold (0.70 log units) above, outside the stated range (below it).
By their numbers in this assay, from the lowest: compounds 1 and 4 (each within the scatter of the next); then compound 2; then compound 3.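

In this assay, 2,6-difluorophenyl in place of 4-cyanophenyl leaves the number within the scatter (a 1.9-fold higher number from compound 1 to compound 4 (0.29 log units; within the scatter)). Compound 4 thus shows that, on this saturated chain carbon, a benzyl group without the nitrile can match compound 1, so the large rises for compound 2 and compound 3 do not follow from losing the nitrile alone. Nothing available here accounts for this result. The compounds shown leave open whether one fluorine on that ring would suffice. They also leave open how an amine or a carboxylic acid in place of the nitrile would read.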